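Series notes: isopropyl for methyl on the shared core

The compounds below may be only part of what the source reports. "The series", "measured", "known", "first", "only" and "open" are said of these compounds alone.

Measured compounds and values:
compound 1, `Cc1nn(-c2ccccc2)c(Oc2ccc(Cl)cc2)c1/C=N/OCc1ccc(C(=O)OC(C)(C)C)cc1`, -8.4%
compound 2, `Cc1nn(C)c(Oc2ccccc2)c1/C=N/OCc1ccc(C(F)(F)F)cc1`, 30.5%
compound 3, `CCOC(=O)c1ccc(CO/N=C/c2c(C)nn(-c3ccccc3)c2Oc2ccc(Cl)cc2)cc1`, 12%

In a functional assay on MCF7 cells (Homo sapiens) for antiproliferative activity, tested at 1 uM (a higher number here means more inhibition at the concentration tested (going by the name of the read-out), a lower number less inhibition), compound 1 gives -8.4%, the lowest of the three numbers. The nearest is compound 3 with 12%, beyond the scatter above compound 1; the furthest is compound 2 with 30.5%, also beyond the scatter. Going by the values given here, the only step between measured compounds that differ in one place is a number 20.4 percentage points higher from compound 1 to compound 3 (beyond the scatter); it concerns the oxygen next to the carbonyl group, not the core.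

Compound 4, `CC(C)c1nn(-c2ccccc2)c(Oc2ccc(Cl)cc2)c1/C=N/OCc1ccc(C(=O)OC(C)(C)C)cc1`, is the next compound to be measured. It differs from compound 1 in one place: isopropyl in place of methyl on an aromatic carbon. The methyl leaves and an isopropyl enters on an aromatic carbon of a five-membered aromatic ring with 2 nitrogen, two ring bonds from the ring atom that bears a 4-chlorophenoxy group and two ring bonds from the ring atom that bears a phenyl group. Among the compounds with values here, no measured step touches this place, so nothing among compounds 1, 2 and 3 tells how the change should run in this assay. The working expectation is therefore no step beyond the scatter, a number 0.4 percentage points higher from compound 1 to compound 4 (within the scatter). Compound 4 is estimated at -8%, between -28% and 14%.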

Compound 4, a percentage reported as inhibition, at one concentration (the size of the read-out at that concentration, not a potency): -4.9%
Estimate against measurement, compound 4: 3.1 percentage points below; the range from low to high includes it.
By their numbers in this assay, from the lowest: compounds 1 and 4 (each within the scatter of the next); then compound 3; then compound 2.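

In this assay, this place on the core, an aromatic carbon of a five-membered aromatic ring with 2 nitrogen, now has its first measured step: isopropyl in place of methyl gives a number 3.5 percentage points higher from compound 1 to compound 4 (within the scatter). On this background, with the phenyl group, the 4-chlorophenoxy group and the tert-butyl ester all kept, going from methyl to isopropyl therefore does not separate the two compounds, and compound 4 at -4.9% still shows no real inhibition, so the step cannot say whether the same change would count on a compound with a larger read-out. No measurement bearing on why the read-out holds at this place is available.

On these data alone, it remains open whether the same change stays as small on the ethyl ester of compound 3, where the read-out starts higher, or on the core of compound 2, which carries other groups in several places. Also open, as far as these compounds go, is how this place responds to groups other than small alkyl ones, such as a hydrogen, a primary amine or a carboxylic acid, and whether a longer chain such as n-butyl behaves like isopropyl.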